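Hydroxy for methoxy on the dimethylaminophenyl analogue

This account rests on a few compounds, and the source may have more. Where it says the series, first, only, none or still open, it means among the compounds named here.

Among the measured compounds shown here, compound 2 `COc1cc(C)cc(-c2nn(CC#N)cc2-c2ccnc(-c3ccc(N(C)C)cc3)c2)c1` gives 10% in a functional assay on KM12 cells (Homo sapiens) for cytotoxicity, read by sulforhodamine B assay, with a stated time of 48 h, tested at 100 nM (on this read-out lower numbers stand for a stronger effect and higher numbers for a weaker effect at the one concentration tested), and stands lowest of the two numbers measured so far. Its nearest neighbour, compound 1 `Cc1cc(O)cc(-c2nn(CC#N)cc2-c2ccnc(-c3ccc(Oc4ccccc4)cc3)c2)c1`, gives 85%, a gap beyond the scatter. For the measured compounds named here, compound 1 and compound 2 differ in more than one place, so no single-point step is known, and nothing can be laid to one change alone.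

Compound 3 `Cc1cc(O)cc(-c2nn(CC#N)cc2-c2ccnc(-c3ccc(N(C)C)cc3)c2)c1` is not yet measured. It differs from compound 2 in one place: hydrogen in place of methyl on an oxygen on an aromatic ring. Compound 1 carries the same hydroxy group as compound 3 and sits at the weak end, whereas compound 2 carries the methoxy group and sits at the strong end; but compound 1 also carries a different group on the far ring, so this does not settle the step.

The expectation is a step from compound 2 to compound 3 in the direction of a weaker effect, of modest size and possibly within the scatter, as a number 25 percentage points higher from compound 2 to compound 3 (beyond the scatter). Compound 3 is estimated at 35%, with a wide range from 8% to 80%.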

Compound 3, a percentage reported as activity, at one concentration (the size of the read-out at that concentration, not a potency): 66%
For compound 3 the middle estimate is 31 percentage points below the measured one; the range from low to high includes it.
By their numbers in this assay, from the lowest: compound 2; then compound 3; then compound 1.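

In this assay, among the compounds shown here, the methoxy to hydroxy change gives the first single-place reading, and it reads as a number 56 percentage points higher from compound 2 to compound 3 (beyond the scatter) with the dimethylamino group held fixed. The methyl on this oxygen therefore matters in its own right, and the weak reading of the hydroxy compounds no longer rests only on compound 1, which also carries phenoxy. With the hydroxy group held fixed, dimethylamino in place of phenoxy on an aromatic carbon reads in this assay as a number 19 percentage points lower from compound 1 to compound 3 (beyond the scatter) and so shows that this second place also counts on its own, although a single pair at a single concentration supports no general rule. Nothing available bears on why either change moves the read-out.

For the compounds shown here, it remains open whether the methoxy to hydroxy step keeps its direction and size with phenoxy in place of dimethylamino, since only one such pair can be read here. Going by these compounds, it is also open how an ethoxy group, a longer alkoxy chain or an amine in place of the methoxy group would read, which would show whether the read-out follows the methyl itself or something broader at this place.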